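Swapping the nitro-bearing ring for a trifluoromethyl ring

The compounds below may be only part of what the source reports. "The series", "measured", "known", "first", "only" and "open" are said of these compounds alone.

The compounds measured so far:
- compound 1, `CN(C(=O)NC(=O)c1ccc(F)c(F)c1)c1nc(C(F)(F)F)c(C(=O)N/N=C/c2ccccc2C(F)(F)F)s1`: 10.4 ug/mL
- compound 2, `CN(C(=O)NC(=O)c1c(Cl)cccc1Cl)c1nc(C(F)(F)F)c(C(=O)N/N=C/c2ccccc2C(F)(F)F)s1`: 8.95 ug/mL
- compound 3, `CN(C(=O)NC(=O)c1cccc([N+](=O)[O-])c1)c1nc(C(F)(F)F)c(C(=O)N/N=C/c2ccccc2C(F)(F)F)s1`: 4.8 ug/mL

All three were tested in a functional assay on HepG2 cells (Homo sapiens) for inhibition, read by MTT assay, with a stated time of 72 h; a higher number here means a weaker inhibitor, a lower number a stronger inhibitor. Compound 3 gives the lowest number of the three in this assay; its step from compound 1, a 2.2-fold lower number from compound 1 to compound 3 (0.34 log units; beyond the scatter), is beyond the scatter, while the step from compound 2, a 1.9-fold lower number from compound 2 to compound 3 (0.27 log units; within the scatter), is within it, so compound 3 can only be said to differ clearly from compound 1.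

Compound 4, `CN(C(=O)NC(=O)c1ccc(C(F)(F)F)cc1)c1nc(C(F)(F)F)c(C(=O)N/N=C/c2ccccc2C(F)(F)F)s1`, is not yet measured. It differs from compound 3 by one change: 4-(trifluoromethyl)phenyl in place of 3-nitrophenyl on a carbonyl carbon.

Among the compounds with values here, the steps that bear on this are those leading into compound 3, a 2.2-fold lower number from compound 1 to compound 3 (0.34 log units; beyond the scatter) and a 1.9-fold lower number from compound 2 to compound 3 (0.27 log units; within the scatter). Both replaced a halogen-carrying ring with the 3-nitrophenyl ring and both gave lower numbers, one of them beyond the scatter. Compound 4 goes the other way, removing the 3-nitrophenyl ring in favour of another halogen-carrying ring, so a modest rise in the number, back toward the values of compound 1 and compound 2, is expected, though the new ring is not one already tested.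

For compound 4 the expected step is a 1.7-fold higher number from compound 3 to compound 4 (0.22 log units; within the scatter). The estimate for compound 4 in this assay is 8 ug/mL, with a range from 4 ug/mL to 16 ug/mL.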

Compound 4, half-maximal inhibitory concentration: 3.64 ug/mL
Beside the measured number, compound 4's estimate is 2.2-fold (0.34 log units) above it, outside the stated range (below it).
By their numbers in this assay, from the lowest: compounds 4, 3, 2 and 1 (each within the scatter of the next, the first and the last beyond it).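

In this assay, putting 4-(trifluoromethyl)phenyl in place of 3-nitrophenyl on the carbonyl carbon gives a 1.3-fold lower number from compound 3 to compound 4 (0.12 log units; within the scatter) and so leaves the two compounds indistinguishable, although the group leaving has 2 hydrogen-bond acceptors and the group entering has 0. The nitro group is therefore not required for a low number at this position, and a fluorine-bearing ring does not by itself bring a high one: the same ring gives a 2.5-fold lower number from compound 2 to compound 4 (0.39 log units; beyond the scatter) when it replaces 2,6-dichlorophenyl and a 2.9-fold lower number from compound 1 to compound 4 (0.46 log units; beyond the scatter) when it replaces 3,4-difluorophenyl. Nothing measured alongside these numbers accounts for the differences between the rings.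

Going by these compounds, all four compounds keep the rest of the molecule unchanged, so it remains open whether the same ranking of rings would hold if the trifluoromethyl-bearing benzylidene end or the shared core were altered. On these data alone, it is also open how a ring carrying an amine or a carboxylic acid would behave on this carbonyl carbon, and whether an unsubstituted phenyl ring would match compound 3 and compound 4 or sit nearer compound 1.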